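A Cyclic Amine in Place of the (2-Cyanoethyl)amino Group

The source may hold more compounds than are shown below. What is called first, only, known or untested is meant among the compounds shown, and "the series" means these compounds.

Compound 1 `C#CCSc1nc(NCCC#N)c2ccncc2n1` was tested in a functional assay on HepG2 cells (Homo sapiens) for inhibition, read by MTT assay, with a stated time of 72 h; a higher number here means a weaker inhibitor, a lower number a stronger inhibitor. In this assay compound 1 gives only a limit, > 80000 nM, which is the limit of > 80000 nM in this assay, at which 1 of the 3 values shown sits. Compound 2 `C#CCSc1nc(Nc2ccc(F)cc2)c2ccncc2n1` gives 10800 nM and compound 3 `C#CCSc1nc(Nc2ccc(Cl)cc2)c2ccncc2n1` gives 36700 nM, so that an at least 7.4-fold lower number from compound 1 to compound 2 (0.86 log units; beyond the scatter) and an at least 2.1-fold lower number from compound 1 to compound 3 (0.33 log units; beyond the scatter); between those two, a 3.4-fold higher number from compound 2 to compound 3 (0.53 log units; beyond the scatter). Compound 4 `C#CCSc1nc(N2CCN(C)CC2)c2ccncc2n1` carries the change (4-methylpiperazin-1-yl in place of (2-cyanoethyl)amino on an aromatic carbon). Among the measured compounds shown here, no measured step puts a cyclic amine at that position, so the two steps from compound 1 show only that compound 1 sits at the weak end and that another group there can lower the number. Compound 4 is therefore expected near 40000 nM (range 8000 nM to 100000 nM), the estimated step being an at least 2.0-fold lower number from compound 1 to compound 4 (0.30 log units; that floor lies within the scatter), with a real chance that only a limit is again reported.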

Compound 4, half-maximal inhibitory concentration: > 80000 nM
Compound 4: no number, only a limit; the forecaster's own chance of this, stated with the estimate: 40%; at least 2.0-fold (0.30 log units) between middle value and limit.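

Compound 1 and compound 4 both give only a limit, so the step between them cannot be read: the limit of > 80000 nM in this assay, at which 2 of the 4 values shown sit. In this assay the compounds shown leave open whether 4-methylpiperazin-1-yl and (2-cyanoethyl)amino differ at all.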